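Notes on the cyclohexanecarboxamide series at the bile acid receptor

The source may hold more compounds than are shown below. What is called first, only, known or untested is meant among the compounds shown, and "the series" means these compounds.

Compound 1 `CCOc1cccc(-c2ccc(CN(C(=O)C3CCCCC3)c3cccc(/C=C/C(=O)OC)c3)cc2)c1` gives 147 nM in an assay on isolated protein with Bile acid receptor (Homo sapiens) as the target; a lower number here means that less compound is needed, a higher number that more compound is needed for the effect. Compound 2 `COC(=O)/C=C/c1cccc(N(Cc2cccc(OC)c2)C(=O)C2CCCCC2)c1` reaches only > 1000 nM in this assay, which is a limit of the assay and not a number, so compound 2 stands at the limit of > 1000 nM in this assay, at which 1 of the 2 values shown sits. Compound 3 `COC(=O)/C=C/c1cccc(N(Cc2ccc(/C=C/C(=O)O)cc2)C(=O)C2CCCCC2)c1` is not yet measured; it differs from compound 2 as follows: 4-(2-carboxyethenyl)phenyl in place of 3-methoxyphenyl on a saturated chain carbon bound to an amide-type nitrogen. Among the measured compounds shown here, no step between measured compounds has been recorded, so the expected change is judged from compound 2 alone. The step that the limit leaves unreadable from compound 2 to compound 3 is expected to stay within the usual scatter. Compound 3 is estimated at 2000 nM, with a range from 400 nM to 10000 nM.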

Compound 3, half-maximal effective concentration: > 1000 nM
Compound 3: a limit, no number (the forecaster's own chance of this, stated with the estimate: 50%); the middle value does not contradict the limit.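

In this assay the values of compound 2 and compound 3 are both limits of the assay, not numbers: the limit of > 1000 nM in this assay, at which 2 of the 3 values shown sit. The step between these two compounds cannot be read. Among the compounds shown here, on the aromatic carbon, 2-carboxyethenyl in place of 3-ethoxyphenyl gives an at least 6.8-fold higher number from compound 1 to compound 3 (0.83 log units; beyond the scatter), the first readable step, so the 3-ethoxyphenyl of compound 1 is favoured over 2-carboxyethenyl there.

Still open, on these data alone, is how an amine or a tetrazole on that aromatic carbon would compare with 3-ethoxyphenyl. Also open, as far as these compounds go, is whether a shorter ether, such as methoxy, would hold the value of compound 1.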